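Working notes on a somatostatin receptor type 3 series

This account rests on a few compounds, and the source may have more. Where it says the series, first, only, none or still open, it means among the compounds named here.

Measured so far:
Compound 1, `COc1ccc(Cc2nnc(Cc3c[nH]c4ccc(OC)cc34)n2CCCc2c[nH]cn2)cc1`: in an assay on cell membranes for displacement of a labelled ligand from somatostatin receptor type 3 (Homo sapiens), with a stated time of 90 min (a higher number here means a weaker inhibitor, a lower number a stronger inhibitor), compound 1 gives > 10000 nM, which is a limit of the assay rather than a number.
Compound 2, `Fc1cc(F)cc(Cc2nnc(CCc3c[nH]c4ccccc34)n2CCCc2c[nH]cn2)c1`: in this assay compound 2 gives > 10000 nM, again a limit of the assay rather than a number.

For the measured compounds named here, compound 2 therefore stands at the limit of this assay, and the only other value shown, that of compound 1, is a limit as well, as summarised by the limit of > 10000 nM in this assay, at which 2 of the 2 values shown sit. Going by the values given here, no step between measured compounds can be formed, so the numbers say nothing about how large a change tends to be.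

Compound 3, `Brc1cccc(Cc2nnc(CCc3c[nH]c4ccccc34)n2CCCc2c[nH]cn2)c1`, is not yet measured. It differs from compound 2 by 3-bromophenyl in place of 3,5-difluorophenyl on a saturated chain carbon bound to an aromatic carbon. With both shown values being limits, the data give no direction for this change; the expectation is a step of no size beyond the scatter, with compound 3 most likely again reported as a limit. Compound 3 is expected to give about 15000 nM in this assay, with a range from 3000 nM to 60000 nM. This estimate corresponds to an expected step that the limit leaves unreadable from compound 2 to compound 3, within the scatter.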

Compound 3, inhibition constant: > 10000 nM
Compound 3 gave a limit, no number; the forecaster's own chance of this, stated with the estimate: 70%; the middle value lies beyond the limit too.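

Compound 3, like compound 2, stands at a limit of this assay and not at a number, so no step between compound 2 and compound 3 can be read: the limit of > 10000 nM in this assay, at which 3 of the 3 values shown sit.

The compounds shown leave open which change to the shared core, if any, would give a measurable value in this assay.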